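Chain extension on the furanone ether series

The compounds below may be only part of what the source reports. "The series", "measured", "known", "first", "only" and "open" are said of these compounds alone.

Two compounds have numbers in an assay on cells for activation of nuclear factor erythroid 2-related factor 2 (Homo sapiens), read by a luciferase reporter, with a stated time of 6 h; on this read-out lower numbers stand for an effect already at smaller amounts and higher numbers for an effect only at larger amounts of compound. Compound 1 `CC1=CC(O/C=C2/C(=O)C(C)[C@H]3C[C@@]23C(C)C)OC1=O` gives 1900 nM in this assay. Compound 2 `CC(C)=CCOC1C=C(C)C(=O)O1` gives 29500 nM in this assay, the highest of the two numbers, and its gap to compound 1 lies beyond the scatter. Among the compounds with values here, no pair of measured compounds differing in one place is available, so no measured step can guide the next move.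

Compound 3 `CC(C)=CCC/C(C)=C/COC1C=C(C)C(=O)O1` differs from compound 2 by 3-methylbut-2-en-1-yl in place of hydrogen on a saturated chain carbon bound to a double-bonded chain carbon. The change lengthens the unsaturated side chain on the core of compound 2 while leaving the rest untouched. Within the data shown here, with nothing measured on chain length, the expectation rests on the single anchor of compound 2 alone. The expected change is a 2.0-fold lower number from compound 2 to compound 3 (0.29 log units; within the scatter), a step toward lower numbers of modest size, possibly within the scatter. Compound 3 is estimated at 15000 nM in this assay, within 5000 nM to 45000 nM.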

Compound 3, half-maximal effective concentration: 16200 nM
Compound 3: the middle estimate sits 1.1-fold (0.03 log units) below what was measured; the measured number falls inside the stated range.
By their numbers in this assay, from the lowest: compound 1; then compounds 3 and 2 (each within the scatter of the next).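

In this assay, 3-methylbut-2-en-1-yl in place of hydrogen on a saturated chain carbon bound to a double-bonded chain carbon gives a 1.8-fold lower number from compound 2 to compound 3 (0.26 log units; within the scatter). Within the data shown here, this is the first measured step, and it shows that this position accepts the added group, although the read-out does not separate compound 2 from compound 3. No evidence on hand bears on this step.

One step within the scatter establishes no trend with chain length on the core of compound 2. On these data alone, it remains open whether a longer chain, a carboxylic acid or an amine in place of 3-methylbut-2-en-1-yl would shift the number beyond the scatter.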